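The source may report more compounds than this note shows. Statements on the series, on what has been measured and on what is new or still open speak of the compounds shown alone.

Compound 1 `CCc1ccccc1N(CC(=O)NCc1ccc(Cl)cc1)S(=O)(=O)c1ccc(C)cc1` anchors this small set: in an assay on CHO cells for displacement of a labelled ligand from prostaglandin E2 receptor EP1 subtype (Homo sapiens) (a higher number here means a weaker inhibitor, a lower number a stronger inhibitor), compound 1 gives 10 nM. Compound 2 `Cc1ccc(S(=O)(=O)N(CC(=O)NCc2ccc(Cl)cc2)c2ccc(C)nc2)cc1` differs only in the group on the sulfonamide nitrogen. In this assay compound 2 returns only a limit of the assay, < 1000 nM, and not a number. Compound 3 `Cc1ccc(S(=O)(=O)N(CC(=O)NCc2ccc(Cl)cc2)c2cccc(C)n2)cc1` carries a 6-methylpyridin-2-yl at the same place. In this assay compound 3 likewise reaches only a limit, < 1000 nM. Compound 3 therefore stands on a limit, one of the two compounds that sit at the limit of < 1000 nM in this assay, at which 2 of the 3 values shown sit. The steps a step that the limit leaves unreadable from compound 1 to compound 2, a step that the limit leaves unreadable from compound 1 to compound 3 and a step that the two limits leave unreadable from compound 2 to compound 3 cannot be sized for this reason. Compound 4 `Cc1ccc(S(=O)(=O)N(CC(=O)NCc2ccc(Cl)cc2)c2ccnn2C)cc1` brings the change (1-methyl-1H-pyrazol-5-yl in place of 6-methylpyridin-2-yl on a sulfonamide nitrogen). No measured step gives a readable size for this exchange of one small aromatic ring for another on the sulfonamide nitrogen, and compound 3 itself is known only as a limit, so neither a size nor a direction can be read from what is shown. Compound 4 is expected to land near the same limit, with an estimated step that the limit leaves unreadable from compound 3 to compound 4 no larger than the scatter. The estimate for compound 4 is 500 nM, within 50 nM to 5000 nM.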

Compound 4, inhibition constant: 398 nM
Compound 4: middle estimate off by 1.3-fold (0.10 log units), on the high side; the range from low to high includes it.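

Among compound 2, compound 3 and compound 4, only compound 4 gives a true number in this assay, so the exchange of 2-ethylphenyl on the sulfonamide nitrogen can now be sized: a 40-fold higher number from compound 1 to compound 4 (1.60 log units; beyond the scatter). At this position, then, 1-methyl-1H-pyrazol-5-yl gives a much weaker inhibitor than 2-ethylphenyl. The steps that link compound 4 to compound 2 and compound 3 cannot be read, because those two compounds carry only a limit and not a number: the limit of < 1000 nM in this assay, at which 2 of the 4 values shown sit.

The compounds shown leave open how a plain phenyl or a cyclohexyl group at this place would compare with 2-ethylphenyl. They also do not separate the ethyl chain of compound 1 from its phenyl ring as the source of the gap.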